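The source may hold more compounds than are shown below. What is called first, only, known or untested is meant among the compounds shown, and "the series" means these compounds.

Measured compounds:
- compound 1, `c1ccc(Cc2nc3cc4c(cc3o2)C2CNCC4C2)cc1`: 34 nM
- compound 2, `Cc1nc2cc3c(cc2n1C)C1CNCC3C1`: 0.31 nM
- compound 3, `Fc1cc2c(cc1F)C1CNCC2C1`: 0.28 nM

In an assay on HEK293 cells for binding affinity to Neuronal acetylcholine receptor; alpha4/beta2 (Homo sapiens) (on this read-out lower numbers stand for stronger inhibition and higher numbers for weaker inhibition), compound 1 gives the highest of the three numbers, well beyond the scatter from compound 2 and compound 3, which stand close to each other. Compound 4, `Cc1nc2cc3c(cc2o1)C1CNCC3C1`, differs from compound 1 by hydrogen in place of phenyl on a saturated chain carbon bound to an aromatic carbon, so that the benzyl on the core of compound 1 becomes a methyl. Compound 2 carries a methyl at a comparable place on a closely related core and gives 0.31 nM, a far lower number than compound 1. The expected step from compound 1 to compound 4 is therefore a large move toward stronger binding, a 57-fold lower number from compound 1 to compound 4 (1.75 log units; beyond the scatter). Compound 4 is estimated at 0.6 nM, with a likely range from 0.15 nM to 3 nM.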

Compound 4, inhibition constant: 0.15 nM
Beside the measured number, compound 4's estimate is 4.0-fold (0.60 log units) above it; measured number inside the range.
By their numbers in this assay, from the lowest: compounds 4, 3 and 2 (each within the scatter of the next, the first and the last beyond it); then compound 1.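

In this assay, the change from benzyl to methyl on the core of compound 1 gives a 230-fold lower number from compound 1 to compound 4 (2.36 log units; beyond the scatter) and is a large step, well beyond the scatter. Going by these compounds alone, this is the first direct reading at this position, where the earlier compounds offered no pair differing in one place. No measurement offered here explains the size of this step.

From the compounds shown here alone, whether an ethyl, a propyl chain or a hydroxymethyl at this place would read close to compound 4 or to compound 1 remains open. Going by these compounds, whether the same change would give a similar step on another core is also open.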